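Methoxy to isopropoxy on the piperidin-1-yl compound

The source may report more compounds than this note shows. Statements on the series, on what has been measured and on what is new or still open speak of the compounds shown alone.

Measured so far in a functional assay on MES-SA cells (Homo sapiens) for inhibition, with a stated time of 72 h, in the presence of a further agent that is not named here; a lower number here means a stronger inhibitor, a higher number a weaker inhibitor:
- compound 1 `CCN(CC)Cc1cc(Cl)c2cccnc2c1O` at 3250 nM; 3240 nM (2 entries)
- compound 2 `COCc1cc(CN2CCCC2)c(O)c2ncccc12` at 10500 nM
- compound 3 `COCc1cc(CN2CCCCC2)c(O)c2ncccc12` at 9550 nM

Compound 3 stands level with compound 2 within the scatter, as the step of a 1.1-fold lower number from compound 2 to compound 3 (0.04 log units; within the scatter) shows. Among the measured compounds shown here, compound 1 (3250 nM; 3240 nM (2 entries)) gives a lower number than compound 3 (9550 nM), but the two differ in more than one place and so form no single step. Repeat readings in this assay agree closely, as the several entries of compound 1 in this assay, 3250 nM; 3240 nM (2 entries) shows.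

The next compound, compound 4 `CC(C)OCc1cc(CN2CCCCC2)c(O)c2ncccc12`, carries isopropyl in place of methyl on an oxygen on a saturated carbon and so turns methoxymethyl into isopropoxymethyl. For the measured compounds named here, no measured step covers this change. Going by the values given here, the one measured step, a 1.1-fold lower number from compound 2 to compound 3 (0.04 log units; within the scatter), exchanges a different group and stays within the scatter, so it offers only weak guidance and sets no direction. No shift beyond the scatter is therefore expected in this assay. The expected change is a 1.1-fold lower number from compound 3 to compound 4 (0.05 log units; within the scatter) and remains within the scatter. For compound 4 the estimated value is 8500 nM, with an expected range from 4000 nM to 17000 nM in this assay.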

Compound 4, half-maximal inhibitory concentration: 5750 nM
The estimate for compound 4 lay 1.5-fold (0.17 log units) above the measured number; the measured number falls inside the stated range.
By their numbers in this assay, from the lowest: compounds 4, 3 and 2 (each within the scatter of the next).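

Working notes on the ether side chain: the earlier step changed only the saturated amine ring, whereas this is the only step shown at the oxygen on a saturated carbon, and in this assay it reads a 1.7-fold lower number from compound 3 to compound 4 (0.22 log units; within the scatter). Isopropyl brings 3 heavy atoms where methyl had 1, so methoxymethyl to isopropoxymethyl adds bulk in carbon alone, with no ring, hydrogen-bond donor or acceptor entering, and the two numbers remain within the scatter of each other. The series therefore shows that this place accepts isopropyl in the piperidin-1-yl compounds with no shift that can be called real, although repeat readings in this assay can agree closely: the several entries of compound 1 in this assay, 3250 nM; 3240 nM (2 entries)

Still open, as far as these compounds go, is whether a group of another kind on this oxygen, such as a benzyl group, or a free hydroxymethyl or carboxylic acid in place of the whole ether chain, would move the number beyond the scatter. Also open, from the compounds shown here alone, is whether isopropoxymethyl behaves the same way with pyrrolidin-1-yl or with a diethylamino group on the other chain.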